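This account rests on a few compounds, and the source may have more. Where it says the series, first, only, none or still open, it means among the compounds named here.

Compound 1 `C#CCOC(=O)C[C@@H]1C(C(=O)OC)=CO[C@@H](O[C@@H]2O[C@H](COC(C)=O)[C@@H](OC(C)=O)[C@H](OC(C)=O)[C@H]2OC(C)=O)/C1=C/C` has been tested in a functional assay on SK-BR-3 cells (Homo sapiens) for antiproliferative activity, read by MTT assay, with a stated time of 72 h; a higher number here means a weaker inhibitor, a lower number a stronger inhibitor. In this assay compound 1 gives only a limit, > 15000 nM. Two related compounds are known there as well. Compound 2 `C/C=C1/[C@H](O[C@@H]2O[C@H](CO)[C@@H](O)[C@H](O)[C@H]2O)OC=C(C(=O)OC)[C@H]1CC(=O)OCC` reaches only a limit in this assay, > 15000 nM. Compound 3 `C/C=C1/[C@H](O[C@@H]2O[C@H](CO)[C@@H](O)[C@H](O)[C@H]2O)OC=C(C(=O)OC)[C@H]1CC(=O)OCc1ccc(OC)c(OC)c1` also shows only a limit in this assay, > 15000 nM. The step between them, a step that the two limits leave unreadable from compound 2 to compound 3, therefore stays unreadable. Compound 4 `C/C=C1/[C@H](O[C@@H]2O[C@H](COC(C)=O)[C@@H](OC(C)=O)[C@H](OC(C)=O)[C@H]2OC(C)=O)OC=C(C(=O)OC)[C@H]1CC(=O)OCCCC` differs from compound 1 by propyl in place of ethynyl on a saturated chain carbon bound to an oxygen next to a carbonyl group. Going by the values given here, no measured step covers an exchange of this kind; what is known is the limit of > 15000 nM in this assay, at which 3 of the 3 values shown sit. Because (the limit of > 15000 nM in this assay, at which 3 of the 3 values shown sit), compound 4 is expected to sit at the limit too. The step that the limit leaves unreadable from compound 1 to compound 4 is expected to show no change beyond the scatter. Compound 4 is estimated at 20000 nM, between 8000 nM and 60000 nM.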

Compound 4, half-maximal inhibitory concentration: > 15000 nM
Compound 4: a limit, no number (the forecaster's own chance of this, stated with the estimate: 85%); the middle value is on the limit's open side.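

Going by these compounds alone, compound 1 and compound 4 each give only a limit, so no step between them can be read. Still open is which change to the shared core, if any, would give a real number in this assay: the limit of > 15000 nM in this assay, at which 4 of the 4 values shown sit.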